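Cyano in place of ring hydrogen on the lactam core

The source may hold more compounds than are shown below. What is called first, only, known or untested is meant among the compounds shown, and "the series" means these compounds.

Measured so far:
compound 1 `O=C1c2ccc(Cl)cc2CN1c1cccnc1` — 10700 nM
compound 2 `O=C1c2ccccc2CN1c1cccnc1` — only a limit

Compound 1 `O=C1c2ccc(Cl)cc2CN1c1cccnc1` gives 10700 nM in an ADME assay on cells for inhibition of cytochrome P450 11B1, mitochondrial (Homo sapiens), read by HTRF; a higher number here means a weaker inhibitor, a lower number a stronger inhibitor. For compound 2 `O=C1c2ccccc2CN1c1cccnc1` this assay reports only a limit, > 3000 nM, so compound 2 stands at the edge of the measurable range and no number is attached to it. The step that the limit leaves unreadable from compound 1 to compound 2 therefore cannot be sized, as the limit of > 3000 nM in this assay, at which 1 of the 2 values shown sits, shows.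

Compound 3 `N#Cc1ccc2c(c1)CN(c1cccnc1)C2=O` differs from compound 2 by cyano in place of hydrogen on an aromatic carbon. Going by the values given here, the only measured step, from compound 1 to compound 2, is unreadable because of the limit of > 3000 nM in this assay, at which 1 of the 2 values shown sits, and it concerns a different group, so no measured step bears directly on the change to compound 3. With compound 2 sitting at a limit, the starting point is itself undefined.

Compound 3 is expected to remain a weak inhibitor, with an estimated step that the limit leaves unreadable from compound 2 to compound 3 that cannot be separated from the scatter given the limit on compound 2. The estimate for compound 3 in this assay is 8000 nM, with a range of 2500 nM to 30000 nM, and a fair chance that only a limit is reported again.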

Compound 3, half-maximal inhibitory concentration: 15500 nM
Estimate against measurement, compound 3: 1.9-fold (0.29 log units) below; measured number inside the range.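

Cyano in place of chloro on this aromatic carbon gives a 1.4-fold higher number from compound 1 to compound 3 (0.16 log units; within the scatter), so in this assay the nitrile and the chloro group cannot be told apart at this position, although they differ in kind and in heavy atoms. Going by these compounds alone, this is the first readable step, and it compares two substituents directly at one place on the shared core rather than a substituent against hydrogen. Compound 2 carries only a limit, > 3000 nM, and the steps that involve it cannot be read, so neither group can be set against hydrogen at this position: the limit of > 3000 nM in this assay, at which 1 of the 3 values shown sits.

On these data alone, whether a substituent on this carbon changes the read-out at all therefore stays open, and a number for compound 2 would be needed to settle it. Also open, as far as these compounds go, is whether an amine or a carboxylic acid on the same aromatic carbon would give a step beyond the scatter from compound 3, or would leave the number where the chloro and nitrile compounds stand.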